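The compounds below may be only part of what the source reports. "The series", "measured", "known", "first", "only" and "open" are said of these compounds alone.

Going by the values given here, in a functional assay on L1210 cells (Mus musculus) for inhibition (on this read-out higher numbers stand for weaker inhibition and lower numbers for stronger inhibition), three compounds have numbers so far. Compound 1 `O=C1/C(=C/c2ccc(Cl)cc2)Cc2ccccc21` gives 54100 nM, compound 2 `O=C1/C(=C/c2ccc(Br)cc2)CCc2ccccc21` gives 202000 nM, and compound 3 `O=C1/C(=C/c2ccc(Cl)cc2)CCCc2ccccc21` gives 51800 nM. Compound 3 thus stands within the scatter of compound 1, while compound 2 shows a higher number, beyond the scatter, which means weaker inhibition. Compound 4 `COc1ccc(/C=C2\CCCc3ccccc3C2=O)cc1` differs from compound 3 by methoxy in place of chloro on an aromatic carbon, para to a large group: methoxy in place of chloro on an aromatic carbon. Among the compounds with values here, no measured pair shows this change, so only a modest shift toward weaker inhibition is expected, possibly none beyond the scatter. The estimated step is a 1.5-fold higher number from compound 3 to compound 4 (0.19 log units; within the scatter). For compound 4 the expected value is 80000 nM, with an estimated range from 30000 nM to 200000 nM.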

Compound 4, half-maximal inhibitory concentration: 340 nM
Beside the measured number, compound 4's estimate is 240-fold (2.37 log units) above it, outside the stated range (below it).
By their numbers in this assay, from the lowest: compound 4; then compounds 3 and 1 (each within the scatter of the next); then compound 2.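

In this assay, methoxy in place of chloro on an aromatic carbon, para to a large group, gives a 150-fold lower number from compound 3 to compound 4 (2.18 log units; beyond the scatter), so the group at this place matters greatly. The earlier compounds shown here carry only chloro or bromo there, and their numbers gave no sign of a step this large. No evidence at hand explains it. Whether the step is particular to methoxy stays open, as a hydroxy group, an ethoxy group or an amine at this place has no number among the compounds shown. Going by these compounds, whether methoxy would do the same on the core of compound 1 also stays open.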